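Adding trifluoromethyl to compound 3: working notes

A few compounds are considered here, and "the series" means these few. Any claim that something is new, unique, unknown or untested is made for them only; others in the source may bear on it.

Measured in a functional assay on MDA-MB-231 cells (Homo sapiens) for inhibition, read by MTT assay, with a stated time of 72 h; on this read-out lower numbers stand for stronger inhibition and higher numbers for weaker inhibition:
- compound 1 `Nc1ccccc1NC(=O)c1ccc(CNCc2nc(-c3ccc(C(F)(F)F)cc3)no2)cc1`: 6870 nM
- compound 2 `Nc1ccccc1NC(=O)c1ccc(CNCc2nc(-c3cccs3)no2)cc1`: 10400 nM
- compound 3 `O=C(NO)c1ccc(CNCc2nc(-c3ccccc3)no2)cc1`: 14700 nM

In this assay compound 3 gives 14700 nM. That is within the scatter of compound 2, and beyond the scatter from the lower number of compound 1.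

Compound 4 `O=C(NO)c1ccc(CNCc2nc(-c3ccc(C(F)(F)F)cc3)no2)cc1` carries one change from compound 3: trifluoromethyl in place of hydrogen on an aromatic carbon. Going by the values given here, the only measured step at this aryl end is a 1.5-fold higher number from compound 1 to compound 2 (0.18 log units; within the scatter), which lies within the scatter. Among the compounds with values here, it was taken on a different core, and no measured pair isolates trifluoromethyl against hydrogen. Compound 1 and compound 3 differ in more than one place, so their gap cannot be assigned to this group.

No change beyond the scatter is therefore expected in this assay. The expected step is a 1.3-fold lower number from compound 3 to compound 4 (0.13 log units; within the scatter). For compound 4 the estimated value is 11000 nM, with an expected range of 4500 nM to 24000 nM.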

Compound 4, half-maximal inhibitory concentration: 12300 nM
Compound 4: the middle estimate sits 1.1-fold (0.05 log units) below what was measured; the measured number falls inside the stated range.
By their numbers in this assay, from the lowest: compounds 1, 2, 4 and 3 (each within the scatter of the next, the first and the last beyond it).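

In this assay, going by these compounds alone, the pair of compound 3 and compound 4 is the first to isolate trifluoromethyl against hydrogen on an aromatic carbon para to a large group, and it gives a 1.2-fold lower number from compound 3 to compound 4 (0.08 log units; within the scatter) on the shared core. With trifluoromethyl held fixed, hydroxy in place of 2-aminophenyl on an amide-type nitrogen gives a 1.8-fold higher number from compound 1 to compound 4 (0.25 log units; within the scatter) and so also leaves the number unresolved from the scatter in this pair. No supporting measurement is available to explain either step.

Going by these compounds, whether a different group at this position, such as a methoxy group, a nitrile or an amine, would move the number beyond the scatter remains open. Also open, on these data alone, is whether the trifluoromethyl step would stay this small on the core of compound 1.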